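This account rests on a few compounds, and the source may have more. Where it says the series, first, only, none or still open, it means among the compounds named here.

Of the compounds shown here, two with a shared core have been measured so far. Compound 1 `Cc1ccc(NC(=S)NC(=O)c2ccc(OCc3ccccc3F)cc2)cc1-c1nc2ccccc2[nH]1` gives 158 nM in an assay on cells for inhibition of Sonic hedgehog protein (Mus musculus), read by a luciferase reporter, with a stated time of 48 h; a higher number here means a weaker inhibitor, a lower number a stronger inhibitor. Compound 2 `Cc1ccc(NC(=O)NC(=O)c2ccc(OCc3ccc(F)cc3)cc2)cc1-c1nc2ccccc2[nH]1` gives 37 nM in this assay, the lowest of the two numbers and a gap to compound 1 that lies beyond the scatter, so compound 2 stands as the stronger inhibitor of the pair.

Compound 3 `O=C(NC(=O)c1ccc(OCc2ccc(F)cc2)cc1)Nc1ccc(Cl)c(-c2nc3ccccc3[nH]2)c1` has not been measured. It differs from compound 2 in one place: chloro in place of methyl on an aromatic carbon. For the measured compounds named here, since no single-point step between measured compounds is available, there is nothing in the data that shows how this particular exchange shifts the number. A swap of one small group for another of the same size on an aromatic ring is, in the absence of other evidence, expected to move the read-out little, with no clear direction and most likely not beyond the scatter.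

On that basis the step from a 1.1-fold higher number from compound 2 to compound 3 (0.03 log units; within the scatter) is estimated to be small, and compound 3 is expected to give about 40 nM in this assay, with a range from 15 nM to 110 nM.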

Compound 3, half-maximal inhibitory concentration: 32 nM
Estimate against measurement, compound 3: 1.3-fold (0.10 log units) above, and the stated range covers the measured number.
By their numbers in this assay, from the lowest: compounds 3 and 2 (each within the scatter of the next); then compound 1.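

In this assay, chloro in place of methyl, on the aromatic carbon ortho to a 1H-benzimidazol-2-yl group and para to a large group, gives a 1.2-fold lower number from compound 2 to compound 3 (0.06 log units; within the scatter). For the compounds shown here, this is the first comparison in the set that isolates a single change, since compound 1 and compound 2 differ in more than one place, and it shows that at this position these two groups, each of one heavy atom, cannot be told apart in this read-out. Nothing measured here offers an explanation for this result.

Only methyl and chloro are shown at this position, so it remains open whether a larger or different group, such as a methoxy group, an amine or a carboxylic acid, would leave the number in the same range or move it beyond the scatter. From the compounds shown here alone, it is also open whether the same exchange would give an equally small step on the background of compound 1, whose other parts differ from those of compound 2 and compound 3.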